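The source may hold more compounds than are shown below. What is called first, only, known or untested is meant among the compounds shown, and "the series" means these compounds.

Compound 1 `C=CCn1c(=O)/c(=C\c2cccc(Cl)c2)[nH]c(=O)/c1=C\c1ccccc1OC` sits second highest among the three numbers measured in a functional assay on U-937 cells (Homo sapiens) for cytotoxicity, read by CCK-8 assay, with a stated time of 72 h (a higher number here means a weaker inhibitor, a lower number a stronger inhibitor), where compound 1 gives 1200 nM. Compound 2 `C=CCn1c(=O)/c(=C\c2cccc(F)c2)[nH]c(=O)/c1=C\c1ccccc1OC` gives 2500 nM in this assay, and compound 3 `C=CCn1c(=O)/c(=C\c2cccc(Cl)c2Cl)[nH]c(=O)/c1=C\c1ccccc1OC` gives 500 nM. The step of a 2.1-fold higher number from compound 1 to compound 2 (0.32 log units; beyond the scatter) swaps one halogen for another on the same aromatic ring, and the step of a 2.4-fold lower number from compound 1 to compound 3 (0.38 log units; beyond the scatter) adds a second chloro to the ring that already carries one, turning 3-chlorophenyl into 2,3-dichlorophenyl.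

Compound 4 `C=CCn1c(=O)/c(=C\c2ccc(Cl)c(Cl)c2)[nH]c(=O)/c1=C\c1ccccc1OC` differs from compound 1 by chloro in place of hydrogen on an aromatic carbon. Going by the values given here, only one measured step bears on this change directly: the addition of a second chloro in a 2.4-fold lower number from compound 1 to compound 3 (0.38 log units; beyond the scatter), which gave a modest lowering of the number. Among the compounds with values here, compound 4 places its added chloro at a different spot on the ring, and there is no measured compound that tests that spot. The nearest guide remains the step to compound 3, so a lowering of similar, modest size is expected rather than none.

On that basis compound 4 is estimated to give 600 nM in this assay, expected between 300 nM and 1500 nM, meaning an estimated step of a 2.0-fold lower number from compound 1 to compound 4 (0.30 log units; within the scatter) from compound 1.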

Compound 4, half-maximal inhibitory concentration: "not active" (no number reported)
The entry for compound 4 holds no number, and the estimate cannot be compared.
By their numbers in this assay, from the lowest: compound 3; then compound 1; then compound 2.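

In this assay compound 4 is entered as "not active" with no number, so no step can be read between compound 4 and compound 1, compound 2 or compound 3. Going by these compounds, how far 3,4-dichlorophenyl stands from 3-chlorophenyl in this read-out therefore stays open. Nothing shown gives a reason for that entry.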